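A few compounds are considered here, and "the series" means these few. Any claim that something is new, unique, unknown or untested is made for them only; others in the source may bear on it.

Measured in an assay for inhibition of HSP60/HSP10 (Homo sapiens), with a stated time of 60 min; on this read-out higher numbers stand for weaker inhibition and lower numbers for stronger inhibition:
Compound 1 `O=C(Nc1cccc(Cl)c1)c1cc(Br)cc(Br)c1O` gives 29000 nM.
Compound 2 `COc1c(Br)cc(Br)cc1C(=O)Nc1ccccc1` gives > 100000 nM, which is a limit of the assay, not a number.
Compound 3 `O=C(Nc1ccccc1)c1cc(Br)ccc1O` gives > 100000 nM, also a limit of the assay.

Among these three, compound 1 is the only one with a number in this assay, while compound 2 and compound 3 both sit at the limit of > 100000 nM in this assay, at which 2 of the 3 values shown sit. Compound 2 thus stands at the limit, with no measured value of its own to build on.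

Compound 4 `COc1c(Br)cccc1C(=O)Nc1ccccc1` differs from compound 2 by hydrogen in place of bromo on an aromatic carbon. Within the data shown here, no step between measured compounds with this same change is available, so the expected size of the step from compound 2 to compound 4 can only be guessed from where compound 2 stands. Among the measured compounds shown here, since compound 2 already gives only a limit in this assay, the most likely outcome is that compound 4 also gives a limit, with no step resolvable beyond the scatter. Compound 4 is therefore estimated at 150000 nM, within 50000 nM to 500000 nM, and the expected step is a step that the limit leaves unreadable from compound 2 to compound 4.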

Compound 4, half-maximal inhibitory concentration: > 100000 nM
Compound 4: a limit, no number (the forecaster's own chance of this, stated with the estimate: 85%); the middle value lies beyond the limit too.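

Compound 2 and compound 4 both stand at a limit of the assay rather than at a number, so no step can be read between them: the limit of > 100000 nM in this assay, at which 3 of the 4 values shown sit. In this assay, as far as these compounds go, the effect of hydrogen in place of bromo on an aromatic carbon remains open.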